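The source may report more compounds than this note shows. Statements on the series, on what has been measured and on what is new or still open speak of the compounds shown alone.

Of the compounds shown here, three built on a shared core have been measured in an ADME assay on liver (Mus musculus) for metabolic stability, read by LC-MS, using microsomes and NADPH; a lower number here means that less of the compound is left, a higher number that more of the compound is left. Compound 2 (`CCCN(Cc1ccc(OCCn2c(=O)ccn(C)c2=O)c(OC)c1)C(CC(=O)O)c1ccc(Cl)cc1`) gives 50% and compound 3 (`COc1cc(CN(CC2CC2)C(CC(=O)O)c2ccc(Cl)cc2)ccc1OCCn1c(=O)ccn(C)c1=O`) gives 42%, two values within the scatter of each other. Compound 1 (`CCCN(Cc1ccc(OCCn2c(=O)ccn(C)c2=O)c(C)c1)C(CC(=O)O)c1ccc(Cl)cc1`) gives 23%, clearly less than either.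

Compound 4 (`CCCN(Cc1ccc(OCCn2c(=O)ccn(C)c2=O)c(OC)c1)C(CC(=O)O)c1ccc2c(c1)CCO2`) has not yet been measured. It keeps everything in compound 2 except one group: a group of 9 heavy atoms (8 carbon, 1 oxygen; one five-membered non-aromatic ring with 1 hetero atom, one six-membered aromatic ring of carbon only) in place of a group of 7 heavy atoms (6 carbon, 1 chlorine; one six-membered aromatic ring of carbon only), on a saturated chain carbon bound to an amine nitrogen and a saturated chain carbon. The 4-chlorophenyl group therefore gives way to a larger group that carries a second ring.

Two measured steps offer some guidance. Methoxy in place of methyl on an aromatic carbon gave a number 27 percentage points higher from compound 1 to compound 2 (beyond the scatter). Cyclopropyl in place of ethyl on a saturated chain carbon gave a number 8 percentage points lower from compound 2 to compound 3 (within the scatter). Neither step touches the 4-chlorophenyl group, so they show only how far a single change has moved this read-out so far, not which way this one will go.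

With 50% for compound 2, and no measured compound beyond it by more than the scatter, a lower number seems somewhat more likely than a higher one. The expected change is a number 12 percentage points lower from compound 2 to compound 4 (beyond the scatter), and its size is uncertain. The estimate for compound 4 is 38%, with an expected range from 20% to 58%.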

Compound 4, percent of the compound remaining: 89%
Compound 4: middle estimate off by 51 percentage points, on the low side; the whole stated range lies below it.
By their numbers in this assay, from the lowest: compound 1; then compounds 3 and 2 (each within the scatter of the next); then compound 4.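

In this assay, the place on the saturated chain carbon bound to an amine nitrogen and a saturated chain carbon now proves able to move the read-out strongly: the change from 4-chlorophenyl to the group with a second ring gives a number 39 percentage points higher from compound 2 to compound 4 (beyond the scatter). Among the compounds shown here, the earlier compounds all carried 4-chlorophenyl, so they could say nothing about this place, and this step is the first to show that what sits there matters for how much compound is left. The entering group differs from 4-chlorophenyl in several ways at once, as it has no chlorine, has a second ring and has one hydrogen-bond acceptor, and there is no further measurement here that could explain the rise.

The compounds shown do not separate these differences, so a single ring carrying a nitrile or an amine in place of the chlorine would be needed to tell whether losing the chlorine alone accounts for the step. On these data alone, it also stays open whether the same exchange would give a similar rise on the methyl-bearing core of compound 1 or the cyclopropyl-bearing core of compound 3.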